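The compounds below may be only part of what the source reports. "The series", "measured", "known", "first", "only" and "open" are said of these compounds alone.

Compound 1 `ClCc1ccc(Cn2cnc3nc(Cl)nc(Cl)c32)cc1`: > 100000 nM
Compound 2 `ClCc1ccccc1Cn1cnc2ncnc(Cl)c21`: > 100000 nM
Compound 3 `ClCc1ccccc1Cn1cnc2nc(Cl)nc(Cl)c21`: > 100000 nM

All three were tested in a functional assay on HT-29 cells (Homo sapiens) for cytotoxicity, read by sulforhodamine B assay, with a stated time of 48 h; a lower number here means that less compound is tolerated, a higher number that more compound is tolerated. The value for compound 1 is a limit of the assay, not a measured number. The same holds for compound 2. The same holds for compound 3.

Compound 3 and compound 2 differ in one place: hydrogen in place of chloro on an aromatic carbon. The step that the two limits leave unreadable from compound 3 to compound 2 cannot be read because both values sit at the limit of > 100000 nM in this assay, at which 3 of the 3 values shown sit. As far as these compounds go, whether this change helps, hurts or does nothing therefore stays open.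

Compound 1 and compound 3 contain the same atoms joined differently; the difference between the two cores is not broken down here.

Compound 4 `ClCc1ccc(Cn2cnc3ncnc(Cl)c32)cc1` has not yet been measured in this assay. Within the data shown here, it differs from compound 1 by hydrogen in place of chloro on an aromatic carbon, which is the same change, at the same kind of place, as the one from compound 3 to compound 2. Since that earlier pair gave no readable step and every measured value stands at the limit, the expectation for compound 4 rests only on compound 1 sitting at > 100000 nM. The step from compound 1 to compound 4 is expected to be about a number no higher from compound 1 to compound 4 (the limit leaves the size open). Compound 4 is therefore estimated at 100000 nM, with a range from 40000 nM to 300000 nM, and most likely the assay will again report only a limit.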

Compound 4, concentration lethal to 50% of the cells: 56200 nM
For compound 4 the middle estimate is 1.8-fold (0.25 log units) above the measured one; measured number inside the range.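

On the core of compound 1, hydrogen in place of chloro on the aromatic carbon between two ring nitrogen atoms gives, in this assay, an at least 1.7-fold lower number from compound 1 to compound 4 (0.25 log units; that floor lies within the scatter). This is only a floor, and by itself it does not establish a real change; the true size stays open because the starting point is a limit of the assay and not a measured number, like most of the values here: the limit of > 100000 nM in this assay, at which 3 of the 4 values shown sit.

The same change on the other core, taking compound 3 to compound 2, gives a step that cannot be read, so there are not two readable steps to set side by side, and the data show neither that the change carries from one core to the other nor that it fails to do so.

Among the compounds shown, only chloro and hydrogen appear on that aromatic carbon, so what an amine, a carboxylic acid or a longer chain there would do in this assay stays open. Also open, as far as these compounds go, is where the true values of compound 1, compound 2 and compound 3 lie, since the assay gives only a limit for each of them.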